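Changing the Aryl Amide in an Inactive Pair

The compounds below may be only part of what the source reports. "The series", "measured", "known", "first", "only" and "open" are said of these compounds alone.

Compound 1 `COc1ccc(C(=O)NC(CC(=O)O)c2ccc(Cl)cc2Cl)cc1`: > 100000 nM, a limit
Compound 2 `COc1ccccc1C(=O)NC(CC(=O)O)c1ccc(Cl)cc1Cl`: > 100000 nM, a limit

In a functional assay on MDA-MB-436 cells (Homo sapiens) for antiproliferative activity, read by MTT assay, with a stated time of 24 h (a lower number here means a stronger inhibitor, a higher number a weaker inhibitor), compound 2 gives > 100000 nM, which is a limit and not a number. Compound 1 gives > 100000 nM, which is also a limit. The record so far therefore holds (the limit of > 100000 nM in this assay, at which 2 of the 2 values shown sit).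

Compound 3 `O=C(O)CC(NC(=O)c1ccc(Cl)cc1Cl)c1ccc(Cl)cc1Cl` keeps the shared core of compound 2 and changes only the aryl group on the amide carbonyl: 2,4-dichlorophenyl in place of 2-methoxyphenyl on a carbonyl carbon. For the measured compounds named here, one measured step bears on this, at the same carbonyl carbon: a step that the two limits leave unreadable from compound 1 to compound 2. It offers no size to carry over, and it shows no sign of movement away from the limit. No change beyond the scatter is expected in this assay, and the expected step is a number no higher from compound 2 to compound 3 (the limit leaves the size open). The estimate for compound 3 is 100000 nM, with an expected range of 30000 nM to 300000 nM.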

Compound 3, half-maximal inhibitory concentration: 57300 nM
The estimate for compound 3 lay 1.7-fold (0.24 log units) above the measured number, within the range that was stated.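

In this assay compound 3, with 2,4-dichlorophenyl on the carbonyl carbon, gives 57300 nM, the only number among the three compounds shown. This position can therefore yield a readable value, which neither methoxyphenyl group had shown. The change gives an at least 1.7-fold lower number from compound 2 to compound 3 (0.24 log units; that floor lies within the scatter) and an at least 1.7-fold lower number from compound 1 to compound 3 (0.24 log units; that floor lies within the scatter), and since both are floors within the scatter, they establish no real gain, while the other two compounds remain limits: the limit of > 100000 nM in this assay, at which 2 of the 3 values shown sit.

The compounds shown leave open how far the two methoxyphenyl amides lie beyond their limits, so the true size of either step stays unknown. They also leave open what a nitrile-bearing or trifluoromethyl-bearing phenyl would give on this carbonyl carbon, and whether any reading survives with an amine in place of the carboxylic acid.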